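Amide-variant series: tolerated concentrations and one unmeasured analogue

The source may hold more compounds than are shown below. What is called first, only, known or untested is meant among the compounds shown, and "the series" means these compounds.

Going by the values given here, compound 1 `Cc1cccc2sc(NC(=O)CN3C(=O)S/C(=C/c4ccco4)C3=O)nc12` is the only member of the series with a numbered read-out: in a functional assay on KCL-22 cells (Homo sapiens) for cytotoxicity, read by propidium iodide staining, with a stated time of 48 h (a higher number here means that more compound is tolerated, a lower number that less compound is tolerated), compound 1 gives 97000 nM. Compound 2 `O=C(CN1C(=O)S/C(=C/c2ccco2)C1=O)Nc1ccc(Cl)cc1C(F)(F)F` sits at a limit of the assay rather than at a number, giving > 100000 nM in this assay; this corresponds to the limit of > 100000 nM in this assay, at which 1 of the 2 values shown sits. Compound 3 `O=C(CN1C(=O)S/C(=C/c2ccco2)C1=O)Nc1nc2ccccc2s1` differs from compound 1 by hydrogen in place of methyl on an aromatic carbon. Among the compounds with values here, no measured pair of the series shares this change, so no step beyond the usual scatter is expected in this assay in either direction. For compound 3 the expected value in this assay is 90000 nM, in the range 45000 nM to 200000 nM. The step of a 1.1-fold lower number from compound 1 to compound 3 (0.03 log units; within the scatter) is estimated to stay within scatter.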

Compound 3, half-maximal cytotoxic concentration: 15300 nM
The estimate for compound 3 lay 5.9-fold (0.77 log units) above the measured number, and the stated range ends above it.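

In this assay, going by these compounds alone, the methyl on this aromatic carbon is the first change to read beyond the scatter (a 6.3-fold lower number from compound 1 to compound 3 (0.80 log units; beyond the scatter)). This position is therefore not silent: less compound is tolerated with hydrogen in place of methyl. Nothing shown here accounts for this step.

Going by these compounds, whether an ethyl group, a methoxy group or an amine on the same aromatic carbon would move the number, and in which direction, stays open. Compound 2 gives no step to read, as its value is a limit: the limit of > 100000 nM in this assay, at which 1 of the 3 values shown sits.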